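Swapping the Aryl Group on the Sulfonyl of a Shared Core

The compounds below may be only part of what the source reports. "The series", "measured", "known", "first", "only" and "open" are said of these compounds alone.

Measured so far:
Compound 1, `CC1CCN(c2c(S(=O)(=O)c3ccc(F)c(Cl)c3)cnc3cc(Cl)ccc23)CC1`: 94%
Compound 2, `CC1CCN(c2c(S(=O)(=O)c3ccc(C#N)cc3)cnc3cc(Cl)ccc23)CC1`: 70%
Compound 3, `CC1CCN(c2c(S(=O)(=O)c3ccc(C#N)cc3)cnc3ccc(F)cc23)CC1`: 75%

All three were tested in an assay on isolated protein for displacement of a labelled ligand from metabotropic glutamate receptor 5 (Homo sapiens), with a stated time of 60 min, tested at 1 uM; a lower number here means less inhibition, a higher number more inhibition at the concentration tested (going by the name of the read-out). Compound 1 is compound 2 with one change, (3-chloro-4-fluorophenyl in place of 4-cyanophenyl on a sulfonyl sulfur), and that change gave a number 24 percentage points higher from compound 2 to compound 1 (beyond the scatter). Compound 3 carries a different core from compound 2; the difference between the two cores is not broken down here, and their two numbers lie within the scatter of each other.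

Compound 4, `CC1CCN(c2c(S(=O)(=O)c3ccc(F)c(Cl)c3)cnc3ccc(F)cc23)CC1`, is compound 3 with the same change, (3-chloro-4-fluorophenyl in place of 4-cyanophenyl on a sulfonyl sulfur), at the same place. Because a number 24 percentage points higher from compound 2 to compound 1 (beyond the scatter) was a modest rise, a similar rise in the number is expected here, a number 17 percentage points higher from compound 3 to compound 4 (beyond the scatter). Compound 4 is therefore estimated at 92%, with a likely range from 82% to 99%.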

Compound 4, a percentage reported as inhibition, at one concentration (the size of the read-out at that concentration, not a potency): 95%
Compound 4: the middle estimate sits 3 percentage points below what was measured; the range from low to high includes it.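

In this assay, putting 3-chloro-4-fluorophenyl in place of 4-cyanophenyl on the sulfonyl sulfur gave a number 20 percentage points higher from compound 3 to compound 4 (beyond the scatter), and the rise carried over from one core to the other at much the same size: the same change on two cores in this assay, a number 24 percentage points higher (beyond the scatter) from compound 2 to compound 1 and a number 20 percentage points higher (beyond the scatter) from compound 3 to compound 4, 4 percentage points apart, within the scatter of two such steps This shows that the change behaved alike on these two cores, but it does not show that it would do so on any other core. Each number is also the size of a read-out at a single concentration, not a potency.

The compounds shown leave open what other groups on the sulfonyl sulfur would give. On these data alone, a phenyl ring carrying a carboxylic acid or an amine, for example, or a longer alkyl chain in place of the ring, remains untested here.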